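A few compounds are considered here, and "the series" means these few. Any claim that something is new, unique, unknown or untested is made for them only; others in the source may bear on it.

Three compounds have been measured in an assay on isolated protein for binding affinity to leukotriene B4 receptor 1 (Homo sapiens), tested at 1 uM; a higher number here means more inhibition at the concentration tested (going by the name of the read-out), a lower number less inhibition:

Compound 1, `CCCCCCc1cc(C(C)=O)c(O)cc1OCCCCC#N`, gives 13%.
Compound 2, `CC(=O)c1cc(CC(C)O)c(OCCCCC#N)cc1O`, gives 6%.
Compound 3, `C=CCc1cc(C(C)=O)c(O)cc1OCCCCC#N`, gives 57%.

Compound 3 stands highest of the three. Its nearest neighbour is compound 1, and the step of a number 44 percentage points higher from compound 1 to compound 3 (beyond the scatter) is large; compound 2 lies furthest away, and the step of a number 51 percentage points higher from compound 2 to compound 3 (beyond the scatter) is larger still. Compound 1 and compound 2 differ from each other only by a number 7 percentage points lower from compound 1 to compound 2 (within the scatter), which stays within the scatter.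

Compound 4, `C=CCc1cc(C(C)=O)c(O)cc1OCCCC`, has not yet been measured. It differs from compound 3 by one change: hydrogen in place of cyano on a saturated chain carbon, four bonds along the chain from an oxygen on an aromatic ring.

None of the three measured steps touches this part of the molecule. All of them alter the group on the saturated chain carbon bound to an aromatic carbon, while the chain carrying the cyano group is kept the same in compound 1, compound 2 and compound 3. So the measured data give no direct guide to the size or direction of the new step; they show only that changes elsewhere can move the read-out a great deal.

Going by the values given here, with no bearing step available, compound 4 is expected to land somewhat below compound 3, at roughly 40%, with a wide range from 15% to 65%, which means an estimated step of a number 17 percentage points lower from compound 3 to compound 4 (beyond the scatter).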

Compound 4, a percentage reported as inhibition, at one concentration (the size of the read-out at that concentration, not a potency): 8%
The estimate for compound 4 lay 32 percentage points above the measured number; the measured number lies below the stated range.
By their numbers in this assay, from the lowest: compounds 2, 4 and 1 (each within the scatter of the next); then compound 3.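

In this assay, replacing cyano with hydrogen on the saturated chain carbon, four bonds along the chain from an oxygen on an aromatic ring, turns 3-cyanopropyl into propyl and gives a large step: a number 49 percentage points lower from compound 3 to compound 4 (beyond the scatter). Going by these compounds alone, this end of the chain had stayed the same in all the earlier compounds, and it now proves to matter: the high number of compound 3 depends on the nitrile here as well as on the group on the saturated chain carbon bound to an aromatic carbon. No measurement at hand explains why removing this group has such an effect.

The compounds shown leave open whether the nitrile is the only end group that keeps the number high, or whether a carboxylic acid, a primary amide or a hydroxyl at the same chain end would do the same. They also leave open whether the chain length matters, which a shorter or longer chain still ending in a nitrile would test.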